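The source may hold more compounds than are shown below. What is called first, only, known or untested is meant among the compounds shown, and "the series" means these compounds.

Measured compounds:
compound 1 `Nc1cccc(-c2cn3nc(-c4cccs4)sc3n2)c1` — > 250000 nM
compound 2 `C=C(Br)C(=O)Nc1cccc(-c2cn3nc(-c4ccc(CC)cc4)sc3n2)c1` — 2200 nM
compound 3 `CCOc1ccc(-c2nn3cc(-c4cccc(N)c4)nc3s2)cc1` — 155000 nM

In a functional assay on L1210 cells (Mus musculus) for inhibition, read by cell counting, with a stated time of 2 days (on this read-out lower numbers stand for stronger inhibition and higher numbers for weaker inhibition), compound 1 returns only a limit, > 250000 nM (the limit of > 250000 nM in this assay, at which 1 of the 3 values shown sits). Compound 2 gives 2200 nM in this assay, the lowest of the two numbers, and compound 3 gives 155000 nM, a gap well beyond the scatter. Compound 4 `C=C(Br)C(=O)Nc1cccc(-c2cn3nc(Cc4cccc(OC)c4)sc3n2)c1` keeps the acrylamide of compound 2 and changes the aryl group (3-methoxybenzyl in place of 4-ethylphenyl on an aromatic carbon). Among the measured compounds shown here, no measured step of this kind exists in the set, so the direction rests on the structural change alone; a modest weakening beyond the scatter is expected. Compound 4 is estimated at 5000 nM, between 1500 nM and 20000 nM, an expected step of a 2.3-fold higher number from compound 2 to compound 4 (0.36 log units; beyond the scatter).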

Compound 4, half-maximal inhibitory concentration: 2000 nM
Estimate against measurement, compound 4: 2.5-fold (0.40 log units) above; the range from low to high includes it.
By their numbers in this assay, from the lowest: compounds 4 and 2 (each within the scatter of the next); then compound 3. At a limit, above all of these: compound 1.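

In this assay, 3-methoxybenzyl in place of 4-ethylphenyl on this aromatic carbon gives a 1.1-fold lower number from compound 2 to compound 4 (0.04 log units; within the scatter) and so leaves the read-out within the scatter. With the acrylamide held, this position therefore takes either group, the benzyl group with its methoxy oxygen as well as the directly attached phenyl group. The earlier compounds shown here offered no pair differing at this position alone. As far as these compounds go, whether an amine or a carboxylic acid on the benzyl ring, or a longer chain in its place, would also be tolerated stays open. No measured evidence shown here bears on why the two groups read alike.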